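The compounds below may be only part of what the source reports. "The series", "measured", "known", "first", "only" and "open" are said of these compounds alone.

Among the measured compounds shown here, in a functional assay on DU-145 cells (Homo sapiens) for inhibition, read by trypan blue exclusion, with a stated time of 72 h (a lower number here means a stronger inhibitor, a higher number a weaker inhibitor), three compounds built on a shared core have numbers so far. Compound 1 `Cn1c(=O)c(C(=O)Nc2ccc(F)cc2F)cc2cnc(Nc3ccc4[nH]ccc4c3)nc21` carries a (2,4-difluorophenyl)carbamoyl group on an aromatic carbon and gives 5000 nM as its value. Compound 2 `Cn1c(=O)c(S(=O)(=O)Cc2ccc(F)cc2F)cc2cnc(Nc3ccc4[nH]ccc4c3)nc21` has a sulfonyl group there instead, with 2,4-difluorobenzyl on the sulfur, and gives 1000 nM as its value. Compound 3 `Cn1c(=O)c(S(=O)(=O)c2ccc(O)cc2)cc2cnc(Nc3ccc4[nH]ccc4c3)nc21` has 4-hydroxyphenyl on that sulfur and gives 250 nM as its value, the lowest number of the three and so the strongest inhibitor among them.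

Compound 4 `Cn1c(=O)c(S(=O)(=O)c2ccc([N+](=O)[O-])cc2F)cc2cnc(Nc3ccc4[nH]ccc4c3)nc21` keeps all of this except one group: 2-fluoro-4-nitrophenyl comes in place of 4-hydroxyphenyl on the sulfonyl sulfur (2-fluoro-4-nitrophenyl in place of 4-hydroxyphenyl on a sulfonyl sulfur). The measured step at that same place is modest (a 4.0-fold lower number from compound 2 to compound 3 (0.60 log units; beyond the scatter)). The large step (a 20-fold lower number from compound 1 to compound 3 (1.30 log units; beyond the scatter)) swaps the whole group on the aromatic carbon, so it bears on this change less directly. For the measured compounds named here, no tested compound carries the entering group, which leaves the guidance thin. Going by the values given here, compound 2 is the one sulfonyl compound without a hydroxy group, and its value of 1000 nM stands above that of compound 3, so a modest move to a higher number is expected in this assay. The expected move is a 2.4-fold higher number from compound 3 to compound 4 (0.38 log units; beyond the scatter) in this estimate. Compound 4 is estimated at 600 nM with an expected range from 200 nM to 1800 nM for repeat measurements.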

Compound 4, half-maximal inhibitory concentration: 400 nM
The estimate for compound 4 lay 1.5-fold (0.18 log units) above the measured number; low and high end bracket the measured number.
By their numbers in this assay, from the lowest: compounds 3 and 4 (each within the scatter of the next); then compound 2; then compound 1.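

In this assay, a hydroxy group on the ring is not required for a value in this range: 2-fluoro-4-nitrophenyl, with 0 hydrogen-bond donors, replaces 4-hydroxyphenyl on the sulfonyl sulfur and gives a 1.6-fold higher number from compound 3 to compound 4 (0.20 log units; within the scatter), so these two compounds cannot be told apart. The absence of a hydroxy group therefore cannot by itself account for the weaker value of compound 2, since compound 4 also lacks one and still shows a 2.5-fold lower number from compound 2 to compound 4 (0.40 log units; beyond the scatter). Nothing presented here offers a measured reason why these two quite different rings on the sulfur give such similar results.

The step from compound 2 to compound 4 changes both the 2,4-difluorobenzyl skeleton and the groups on the ring, so the compounds shown do not separate the effect of the extra carbon in the benzyl group from that of the nitro and fluoro groups. A plain phenyl or a 2,4-difluorophenyl group on the sulfur would help to separate them, and a 4-aminophenyl or 4-carboxyphenyl group would show how far this position accepts an amine or a carboxylic acid.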